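Furan-2-yl for Phenyl in a Level Series

The source may report more compounds than this note shows. Statements on the series, on what has been measured and on what is new or still open speak of the compounds shown alone.

In a functional assay on MCF7 cells (Homo sapiens) for antiproliferative activity, read by fluorescence, with a stated time of 3 days (a lower number here means a stronger inhibitor, a higher number a weaker inhibitor), compound 3 `CCCCCSc1nc(OC(=O)c2ccccc2)c2cn[nH]c2n1` gives 18900 nM. It stands level with compound 1 `CCCCCSc1nc(OC(=O)CC(C)(C)C)c2cn[nH]c2n1`, which gives 18900 nM, and with compound 2 `CCCCCSc1nc(OC(=O)c2cc3ccccc3o2)c2cn[nH]c2n1`, which gives 18900 nM. The unmeasured compound 4 `CCCCCSc1nc(OC(=O)c2ccco2)c2cn[nH]c2n1` differs from compound 3 by a single change: furan-2-yl in place of phenyl on a carbonyl carbon. This puts furan-2-yl in place of phenyl on a carbonyl carbon.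

All three measured steps were made at that same place. Neopentyl gives way to 1-benzofuran-2-yl in no change at the digits printed from compound 1 to compound 2 (within the scatter), to phenyl in no change at the digits printed from compound 1 to compound 3 (within the scatter), and 1-benzofuran-2-yl gives way to phenyl in no change at the digits printed from compound 2 to compound 3 (within the scatter). Among the compounds with values here, none of these steps exceeds the scatter, although no furan-2-yl compound has yet been measured. On the evidence of these three compounds, no step beyond the scatter is expected in this assay, and so no direction is favoured. The expected change is no change at the digits printed from compound 3 to compound 4 (within the scatter). For compound 4 the estimated value is 18900 nM, with an expected range of 10000 nM to 33000 nM.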

Compound 4, half-maximal inhibitory concentration: 18900 nM
Compound 4: middle estimate and measured number agree at the digits printed, and the stated range covers the measured number.
By their numbers in this assay, from the lowest: compounds 1, 2, 3 and 4 (each within the scatter of the next).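

Furan-2-yl on the carbonyl carbon gives no change at the digits printed from compound 3 to compound 4 (within the scatter) against phenyl, no change at the digits printed from compound 2 to compound 4 (within the scatter) against 1-benzofuran-2-yl and no change at the digits printed from compound 1 to compound 4 (within the scatter) against neopentyl in this assay. The level read-out at this position therefore now extends to a five-membered aromatic ring with one hetero atom, alongside the six-membered carbon ring of phenyl, 1-benzofuran-2-yl and the open-chain neopentyl. No available evidence accounts for this flat result.

Going by these compounds, whether a pyridine ring, a carboxylic acid or a longer chain on this carbonyl carbon would shift the number remains open. On these data alone, all four compounds carry the shared core and its pentyl chain unchanged, so the effect of altering either remains open too.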